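One chloro removed: from compound 2 to compound 3

The source may report more compounds than this note shows. Statements on the series, on what has been measured and on what is new or still open speak of the compounds shown alone.

Measured so far:
compound 1 `Cc1[nH]n(-c2nc3ccccc3n2C)c(=O)c1C`, in an assay on isolated protein for inhibition of alpha-ketoglutarate-dependent dioxygenase alkB homolog 3 (Homo sapiens), read by polymerase chain reaction, with a stated time of 1 h, tested at 10 mM (a lower number here means less inhibition, a higher number more inhibition at the concentration tested (going by the name of the read-out)), compound 1 gives 21%
compound 2 `Cc1[nH]n(-c2nc3ccccc3[nH]2)c(=O)c1Cc1ccc(Cl)cc1Cl`, in this assay compound 2 gives 11%

Compound 2 has the lower of the two numbers, but its nearest neighbour, compound 1, sits within the scatter, so no order can be read between them. Compound 3 `Cc1[nH]n(-c2nc3ccccc3[nH]2)c(=O)c1Cc1ccc(Cl)cc1` differs from compound 2 only in hydrogen in place of chloro on an aromatic carbon. Among the compounds with values here, no measured pair shows such a change, and both measured values are low, so the step is expected to be small, a number 1 percentage points higher from compound 2 to compound 3 (within the scatter), not beyond the scatter. Compound 3 is estimated at 12%, between 0% and 30%.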

Compound 3, a percentage reported as inhibition, at one concentration (the size of the read-out at that concentration, not a potency): 46%
Compound 3: middle estimate off by 34 percentage points, on the low side; measured number outside the range, above it.
By their numbers in this assay, from the lowest: compounds 2 and 1 (each within the scatter of the next); then compound 3.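

Within this assay the change from 2,4-dichlorophenyl to 4-chlorophenyl gives a number 35 percentage points higher from compound 2 to compound 3 (beyond the scatter) as the first step of the series that can be read. The carbon ortho to a large group is thus a place where a single chloro counts, since only that atom separates the two compounds. Nothing shown explains the size of this step.

Open, from the compounds shown here alone, is how a fluoro, a methoxy or an amine would read on that same carbon. Also open, going by these compounds, is what happens when the remaining chloro gives way to hydrogen.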